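Pyrrolidine in place of triazole on the ethyl side chain

The source may report more compounds than this note shows. Statements on the series, on what has been measured and on what is new or still open speak of the compounds shown alone.

Compound 1 `Cn1ncc(Cl)c1-c1cc(C(=O)N[C@@H]2CN[C@H](CCn3cncn3)C[C@H]2c2ccc(Cl)c(Cl)c2)oc1Cl` carries a 2-(1H-1,2,4-triazol-1-yl)ethyl chain on the shared core. Among the measured compounds shown here, in a functional assay on OVCAR-8 cells (Homo sapiens) for antiproliferative activity (a higher number here means a weaker inhibitor, a lower number a stronger inhibitor), compound 1 gives 1560 nM, the highest of the three numbers so far, though within the usual scatter of both other compounds. Compound 2 `Cn1ncc(Cl)c1-c1cc(C(=O)N[C@H]2CNCC[C@@H]2c2ccc(C(F)(F)F)cc2)oc1Cl` gives 900 nM in this assay, and compound 3 `CC(=O)NCC[C@@H]1C[C@@H](c2ccc(F)c(F)c2)[C@H](NC(=O)c2cc(-c3c(Cl)cnn3C)c(Cl)o2)CN1` gives 880 nM. For the measured compounds named here, none of these three pairs differs in a single place, so no measured step within the set can guide the next one.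

Compound 4 `Cn1ncc(Cl)c1-c1cc(C(=O)N[C@@H]2CN[C@H](CCN3CCCC3)C[C@H]2c2ccc(Cl)c(Cl)c2)oc1Cl` departs from compound 1 by pyrrolidin-1-yl in place of 1H-1,2,4-triazol-1-yl on a saturated chain carbon, two bonds along the chain from a saturated ring carbon. Cut one bond further out, the same change reads 2-(1H-1,2,4-triazol-1-yl)ethyl to 2-(pyrrolidin-1-yl)ethyl. Going by the values given here, no measured compound varies this chain terminus, so the three numbers give no size for such a move. The step of a 1.3-fold lower number from compound 1 to compound 4 (0.11 log units; within the scatter) is therefore expected to stay within the scatter, with no firm direction. Compound 4 is expected at 1200 nM, with a range from 400 nM to 4000 nM.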

Compound 4, half-maximal inhibitory concentration: 1840 nM
Compound 4: middle estimate off by 1.5-fold (0.19 log units), on the low side; measured number inside the range.
By their numbers in this assay, from the lowest: compounds 3, 2, 1 and 4 (each within the scatter of the next, the first and the last beyond it).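

Among the compounds shown here, exchanging 1H-1,2,4-triazol-1-yl for pyrrolidin-1-yl on the ethyl chain gives a 1.2-fold higher number from compound 1 to compound 4 (0.07 log units; within the scatter) in this assay and is the first measured step at this chain terminus. With 5 heavy atoms on both sides, a five-membered aromatic ring with 3 hetero atoms and a five-membered non-aromatic ring with 1 hetero atom therefore read alike here. Nothing on hand explains this equivalence.

Going by these compounds, whether a morpholin-4-yl group, a dimethylamino group, a carboxylic acid or a longer chain at this terminus would also stay within the scatter remains open. Also open, on these data alone, is whether the same exchange would read alike on the difluorophenyl series of compound 3, since this single pair carries only the dichlorophenyl group.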